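Acetyl at the phenyl of compound 1

The compounds below may be only part of what the source reports. "The series", "measured", "known", "first", "only" and "open" are said of these compounds alone.

Compound 1 `c1ccc(-c2cn3ccnc3c(-c3ccc4ncn(C5CCCCC5)c4c3)n2)cc1` gives 28.7% in a functional assay on MDA-MB-435 cells (Homo sapiens) for inhibition, read by sulforhodamine B assay, with a stated time of 48 h, tested at 10 uM (on this read-out higher numbers stand for more inhibition at the one concentration tested (going by the name of the read-out) and lower numbers for less inhibition), the higher of the two numbers here. Compound 2 `O=Cc1ccc(-c2cn3ccnc3c(-c3ccc4ncn(C5CCCCC5)c4c3)n2)cc1` gives 13%, and the step of a number 15.7 percentage points lower from compound 1 to compound 2 (beyond the scatter) is the only one in hand. Compound 3 `CC(=O)c1ccc(-c2cn3ccnc3c(-c3ccc4ncn(C5CCCCC5)c4c3)n2)cc1` carries the change (acetyl in place of hydrogen on an aromatic carbon). This change is a close relative of the formyl step, so a drop of similar size is expected, and the expected step is a number 13.7 percentage points lower from compound 1 to compound 3 (beyond the scatter). For compound 3 the estimate is 15%, with a range from 2% to 30% in this assay.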

Compound 3, a percentage reported as inhibition, at one concentration (the size of the read-out at that concentration, not a potency): 6%
Estimate against measurement, compound 3: 9 percentage points above, and the stated range covers the measured number.
By their numbers in this assay, from the lowest: compounds 3 and 2 (each within the scatter of the next); then compound 1.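

With acetyl, a number 22.7 percentage points lower from compound 1 to compound 3 (beyond the scatter), so in this assay two carbonyl-bearing groups on this aromatic carbon, para to a large group, now fall on the same side of compound 1. Formyl and acetyl are not told apart here: a number 7 percentage points lower from compound 2 to compound 3 (within the scatter). No measured evidence accounts for the loss.

Still open, from the compounds shown here alone, is whether the loss follows the carbonyl or comes with any group at this carbon. An amine, a methoxy group or a carboxylic acid in the same place would separate these readings.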